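The source may hold more compounds than are shown below. What is called first, only, known or untested is meant among the compounds shown, and "the series" means these compounds.

Working notes on the series. Among the measured compounds shown here, in an ADME assay on microsomes from liver (Mus musculus) for metabolic stability, read by LC-MS, with a stated time of 10 min, tested at 0.5 uM (on this read-out lower numbers stand for a less stable compound and higher numbers for a more stable compound), compound 1 (`c1ccc2c(c1)CN[C@@H](CN(CCCN1CCNCC1)[C@H]1CCCc3cccnc31)C2`) gives 92% and compound 2 (`c1cnc2c(c1)CCC[C@@H]2N(CCCN1CCNCC1)Cc1nc2ccccc2[nH]1`) gives 68% on the same scale, so compound 1 holds the higher of the only two numbers available. Compound 3 (`c1ccc2c(c1)CN[C@@H](CN(CC[C@H]1CCCNC1)[C@H]1CCCc3cccnc31)C2`) has not been measured. The change from compound 1 to compound 3 (piperidin-3-yl in place of (piperazin-1-yl)methyl on a saturated chain carbon, two bonds along the chain from an amine nitrogen) puts piperidin-3-yl in place of (piperazin-1-yl)methyl on a saturated chain carbon, two bonds along the chain from an amine nitrogen.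

For the measured compounds named here, the one measured step (a number 24 percentage points lower from compound 1 to compound 2 (beyond the scatter)) swaps 1,2,3,4-tetrahydroisoquinolin-3-yl for 1H-benzimidazol-2-yl at a different place. It therefore bears only indirectly, as a guide to how far a single change can move this series. No measurement covers the present change. Compound 1 at 92% leaves little room upward, so a small downward move is expected, smaller than the measured step but uncertain. The expected step (a number 10 percentage points lower from compound 1 to compound 3 (within the scatter)) is only an estimate and may fall within the scatter. The estimated value for compound 3 is 82% with 62% to 98% as the expected range.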

Compound 3, percent of the compound remaining: 56%
Compound 3: middle estimate off by 26 percentage points, on the high side; measured number below the stated range.
By their numbers in this assay, from the lowest: compound 3; then compound 2; then compound 1.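

In this assay, the place on a saturated chain carbon, two bonds along the chain from an amine nitrogen, proves sensitive: piperidin-3-yl in place of (piperazin-1-yl)methyl gives a number 36 percentage points lower from compound 1 to compound 3 (beyond the scatter). Together with a number 24 percentage points lower from compound 1 to compound 2 (beyond the scatter), this shows that changes at two different places on compound 1 can each move the number beyond the scatter. The present change swaps a ring with 2 hetero atoms for one with 1 hetero atom and also brings in a defined stereocentre, and no available measurement explains the drop or shows which of these differences matters.

Still open, from the compounds shown here alone, is whether piperidin-4-yl, the opposite configuration of piperidin-3-yl, or a 2-(morpholin-4-yl)ethyl group at this place would give a number nearer to that of compound 1. Also open, going by these compounds, is whether the same exchange would produce a step of similar size with 1H-benzimidazol-2-yl in place of 1,2,3,4-tetrahydroisoquinolin-3-yl.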